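Swapping a Pyridine for an Ester on Compound 1

The source may report more compounds than this note shows. Statements on the series, on what has been measured and on what is new or still open speak of the compounds shown alone.

Compound 1 `O=C(CSc1nc2c(c(=O)n1-c1ccccc1)SCC2)Nc1ccc(-c2ccccn2)cc1` stands as the more potent of the two compounds measured in an assay on L cells for inhibition of Protein-serine O-palmitoleoyltransferase porcupine (Mus musculus), read by reporter gene assay, with a stated time of 24 h; on this read-out higher numbers stand for an effect only at larger amounts of compound and lower numbers for an effect already at smaller amounts: compound 1 gives 4 nM, while compound 2 `O=C(CSc1nc2c(c(=O)n1-c1ccccc1)SCC2)Nc1nc(-c2ccccc2)cs1` gives 350 nM, a gap well beyond the usual scatter. Compound 3 `CCOC(=O)c1ccc(NC(=O)CSc2nc3c(c(=O)n2-c2ccccc2)SCC3)cc1` has not been measured. It differs from compound 1 in one place: ethoxycarbonyl in place of pyridin-2-yl on an aromatic carbon, an ethoxycarbonyl in place of pyridin-2-yl on an aromatic carbon. Within the data shown here, no measured pair shows a change of this kind, so the step is expected to be a moderate loss, a 10-fold higher number from compound 1 to compound 3 (1.00 log units; beyond the scatter). Compound 3 is estimated at 40 nM, within a range from 8 nM to 200 nM.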

Compound 3, half-maximal effective concentration: 300 nM
Compound 3: middle estimate off by 7.5-fold (0.88 log units), on the low side; measured number outside the range, above it.
By their numbers in this assay, from the lowest: compound 1; then compounds 3 and 2 (each within the scatter of the next).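

At this aromatic carbon, para to a large group, the substituent matters greatly in this assay: ethoxycarbonyl in place of pyridin-2-yl gives a 75-fold higher number from compound 1 to compound 3 (1.88 log units; beyond the scatter) and a large loss of potency. Among these compounds, this is the first direct view of a single change at this position, and it shows that pyridin-2-yl cannot be replaced by ethoxycarbonyl without a heavy cost. Nothing available explains the size of this step.

On these data alone, it remains open whether the ring of pyridin-2-yl or its nitrogen counts most. Phenyl or pyridin-3-yl at this place would help separate the two.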